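The source may report more compounds than this note shows. Statements on the series, on what has been measured and on what is new or still open speak of the compounds shown alone.

Measured so far in a functional assay on HL-60 cells (Homo sapiens) for antiproliferative activity, read by MTT assay, with a stated time of 48 h; on this read-out higher numbers stand for weaker inhibition and lower numbers for stronger inhibition:
- compound 1 `COC/C1=C/C[C@](C)(CCC=C(C)C)/C=C/[C@@H](OC(=O)C=C(C)C)[C@](C)(O)/C=C/C1=O`: 3070 nM
- compound 2 `CC(C)=CCC[C@]1(C)/C=C/[C@@H](OC(=O)C=C(C)C)[C@](C)(O)/C=C/C(=O)/C(CN2CCN(C)CC2)=C\C1`: 840 nM

Of these two, compound 2 has the lower number, so it shows the stronger inhibition. Next is compound 3 `CC(C)=CCC[C@]1(C)/C=C/[C@@H](OC(=O)C=C(C)C)[C@](C)(O)/C=C/C(=O)/C(COC(=O)c2ccc([N+](=O)[O-])cc2)=C\C1`, not yet measured in this assay. It carries ((4-nitrophenyl)carbonyl)oxy in place of 4-methylpiperazin-1-yl on a saturated chain carbon bound to a double-bonded ring carbon.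

Going by the values given here, only one measured step bears on this change, and it sits at the same place: a 3.7-fold lower number from compound 1 to compound 2 (0.56 log units; beyond the scatter). That step is modest but beyond the scatter. Compound 3 gives up the 4-methylpiperazin-1-yl group that came with the step of a 3.7-fold lower number from compound 1 to compound 2 (0.56 log units; beyond the scatter), so a move back to a higher number is expected, of similar modest size. Among the compounds with values here, a single step cannot show how ((4-nitrophenyl)carbonyl)oxy compares with methoxy, and no compound with that group has been measured, so the range stays wide.

The estimate means a 2.1-fold higher number from compound 2 to compound 3 (0.33 log units; beyond the scatter), an expected move towards weaker inhibition. For compound 3 the expected value is 1800 nM, with an estimated range of 600 nM to 5500 nM.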

Compound 3, half-maximal inhibitory concentration: 830 nM
Estimate against measurement, compound 3: 2.2-fold (0.34 log units) above; measured number inside the range.
By their numbers in this assay, from the lowest: compounds 3 and 2 (each within the scatter of the next); then compound 1.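

In this assay the place on a saturated chain carbon bound to a double-bonded ring carbon does not separate ((4-nitrophenyl)carbonyl)oxy from 4-methylpiperazin-1-yl, with a 1.0-fold lower number from compound 2 to compound 3 (0.01 log units; within the scatter) for this exchange. Measured against the methoxy compound, the new group gives a 3.7-fold lower number from compound 1 to compound 3 (0.57 log units; beyond the scatter) and the earlier group gives a 3.7-fold lower number from compound 1 to compound 2 (0.56 log units; beyond the scatter), so the gain over methoxy is not tied to 4-methylpiperazin-1-yl and appears with either a six-membered non-aromatic ring with 2 hetero atoms or a six-membered aromatic ring of carbon only. No measurement at hand accounts for these two different groups giving numbers within the scatter of each other.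

On these data alone, it remains open whether a ring is needed at all, since a free hydroxyl, a primary amine or a longer open alkyl chain at this place would test the gain over methoxy without either ring. As far as these compounds go, it also remains open whether the nitro group on the aromatic ring contributes, which an unsubstituted benzoyloxy group at the same place would show, and whether the link through oxygen and carbonyl matters, which a benzylamino group would help to separate.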